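Glucagon antagonist series: trifluoromethylphenyl placement, working notes

The source may hold more compounds than are shown below. What is called first, only, known or untested is meant among the compounds shown, and "the series" means these compounds.

Measured so far in this assay:
compound 1 `CC(C)(C)CC[C@H](c1ccc(C(=O)NCc2nn[nH]n2)cc1)N1C(=O)C(c2cccc(C(F)(F)F)c2)=N[C@]12CC[C@@H](C(C)(C)C)CC2` 180 nM
compound 2 `CC[C@H]1CC[C@]2(CC1)N=C(c1cc(Cl)cc(Cl)c1)C(=O)N2[C@H](CCC(C)(C)C)c1ccc(C(=O)NCc2nn[nH]n2)cc1` 66 nM
compound 3 `CC(C)CC[C@H](c1ccc(C(=O)NCc2nn[nH]n2)cc1)N1C(=O)C(c2cc(Cl)cc(Cl)c2)=N[C@]12CC[C@@H](C(C)(C)C)CC2` 150 nM

In a functional assay on CHO cells for antagonist activity at Glucagon receptor (Homo sapiens), read by cAMP accumulation, with stated times of 30 min and 45 min (a higher number here means a weaker inhibitor, a lower number a stronger inhibitor), compound 1 gives 180 nM, the highest of the three numbers. Compound 3 gives 150 nM, which lies within the scatter of compound 1, so the two are not distinguished. Compound 2 gives 66 nM, a number below compound 1 by more than the scatter; compound 2 also differs from compound 1 in more than one place, so no single change can be read from that gap.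

Compound 4 `CC(C)(C)CC[C@H](c1ccc(C(=O)NCc2nn[nH]n2)cc1)N1C(=O)C(c2ccc(C(F)(F)F)cc2)=N[C@]12CC[C@@H](C(C)(C)C)CC2` keeps the shared core of compound 1 and differs only by 4-(trifluoromethyl)phenyl in place of 3-(trifluoromethyl)phenyl on a carbon with a double bond to nitrogen. For the measured compounds named here, no measured pair shows this change, so its size is not anchored by any measured step. With the same atoms joined differently and nothing in the data pointing either way, the step is expected to stay within the scatter, with a wide range to cover the lack of a precedent. Compound 4 is estimated at 250 nM, between 80 nM and 800 nM, giving an expected step of a 1.4-fold higher number from compound 1 to compound 4 (0.14 log units; within the scatter).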

Compound 4, half-maximal inhibitory concentration: 160 nM
Compound 4: middle estimate off by 1.6-fold (0.19 log units), on the high side; the measured number falls inside the stated range.
By their numbers in this assay, from the lowest: compound 2; then compounds 3, 4 and 1 (each within the scatter of the next).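

In this assay, for the compounds shown here, 4-(trifluoromethyl)phenyl in place of 3-(trifluoromethyl)phenyl on the carbon with a double bond to nitrogen gives a 1.1-fold lower number from compound 1 to compound 4 (0.05 log units; within the scatter) and forms the only single-place comparison. The earlier compounds shown here could not address this position, as compound 1, compound 2 and compound 3 all differ from one another in more than one place. Here, the two placements of the trifluoromethyl group on the phenyl ring are not distinguished, and no supporting measurement offers an explanation for this result.

Still open, from the compounds shown here alone, is whether a nitrile, a methoxy group or an amine on this phenyl ring would give a number separated from compound 1 by more than the scatter. Also open, going by these compounds, is whether the same exchange would read the same way on the core of compound 2.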